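A few compounds are considered here, and "the series" means these few. Any claim that something is new, unique, unknown or untested is made for them only; others in the source may bear on it.

Compound 1 `O=c1ccoc(/C=C/c2ccccc2)c1` and compound 2 `COc1ccc(/C=C/c2cc(=O)cco2)cc1` share a core, and in a functional assay on 786-0 cells (Homo sapiens) for inhibition, read by sulforhodamine B assay, with a stated time of 48 h (a higher number here means a weaker inhibitor of growth, a lower number a stronger inhibitor of growth), compound 1 gives 410 uM while compound 2 gives 377 uM. The change between them, (methoxy in place of hydrogen on an aromatic carbon), made a step of a 1.1-fold lower number from compound 1 to compound 2 (0.04 log units; within the scatter). Compound 3 `COc1ccc(/C=C/C2CC=CC(=O)O2)cc1OC` is built on a different core; how the two cores differ is not broken down here. In this assay compound 3 gives 10.9 uM, the lowest of the three numbers and the strongest inhibitor of growth, with steps to compound 2 and compound 1 both beyond the scatter.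

Compound 4 `COc1cc(OC)c(OC)cc1/C=C/C1CC=CC(=O)O1` is compound 3 with methoxy in place of hydrogen on an aromatic carbon. This is the same kind of change as from compound 1 to compound 2, but not the same: in compound 2 the entering methoxy stands para to a group of 9 heavy atoms, whereas in compound 4 it stands ortho to a group of 9 heavy atoms, meta to a methoxy group and para to a methoxy group. Resting on compound 1 and compound 2, whose step a 1.1-fold lower number from compound 1 to compound 2 (0.04 log units; within the scatter) lay within the scatter, the step from compound 3 to compound 4 in this assay is expected to be a 1.2-fold lower number from compound 3 to compound 4 (0.08 log units; within the scatter). Compound 4 is therefore estimated at 9 uM, likely between 3 uM and 30 uM.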

Compound 4, concentration for growth inhibition (reported as GI): 6 uM
Compound 4: the middle estimate sits 1.5-fold (0.18 log units) above what was measured; the range from low to high includes it.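

In this assay, methoxy in place of hydrogen on an aromatic carbon made a step of a 1.8-fold lower number from compound 3 to compound 4 (0.26 log units; within the scatter). Set beside the step on the other core, the change reads alike on both cores: the same change on two cores in this assay, a 1.1-fold lower number (0.04 log units; within the scatter) from compound 1 to compound 2 and a 1.8-fold lower number (0.26 log units; within the scatter) from compound 3 to compound 4, 1.7-fold (0.22 log units) apart, within the scatter of two such steps. For the compounds shown here, this shows only that the change gave no step beyond the scatter on either core; it does not show that a real shift carries from one core to the other, and with a single pair on each core, and the entering methoxy standing para to a group of 9 heavy atoms in compound 2 but ortho to such a group in compound 4, it says nothing about the same placement on both cores.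

The compounds shown leave open whether another group at the place taken by the entering methoxy, such as a fluorine, an amine or a carboxylic acid, would give a larger step on either core. They also leave open how a longer chain in place of the methoxy groups of compound 3 would read.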